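This account rests on a few compounds, and the source may have more. Where it says the series, first, only, none or still open, it means among the compounds named here.

Measured so far in a functional assay on the whole organism with Mus musculus as the target, with a stated time of 90 min, at a dose of 25 umol/kg by the oral route; on this read-out lower numbers stand for a weaker effect and higher numbers for a stronger effect at the one dose given:
- compound 1 `NC(=O)CC[C@H](NC(=O)CN(c1nc(Cl)nc2c1ncn2C1CCCCO1)C1CC1)C(=O)OCc1ccccc1` gives 37.8%
- compound 2 `O=C(CN(c1nc(Cl)nc2c1ncn2C1CCCCO1)C1CC1)N[C@@H](CO)C(=O)OCc1ccccc1` gives 32.2%

Compound 2 holds the lower of the two numbers, with compound 1 the nearest and only neighbour; the step of a number 5.6 percentage points lower from compound 1 to compound 2 (within the scatter) lies within the scatter, so the two compounds cannot be ranked against each other on this read-out.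

Compound 3 `CC(C)[C@H](NC(=O)CN(c1nc(Cl)nc2c1ncn2C1CCCCO1)C1CC1)C(=O)OCc1ccccc1` is not yet measured. It differs from compound 2 as follows: isopropyl in place of hydroxymethyl on a saturated chain carbon bound to an amide-type nitrogen and a carbonyl carbon. Among the measured compounds shown here, the only measured step, a number 5.6 percentage points lower from compound 1 to compound 2 (within the scatter), also alters the group on that same saturated chain carbon, and it did not move the read-out beyond the scatter. For the measured compounds named here, no measured step introduces an isopropyl, so the direction of the change to compound 3 rests on no direct precedent.

Given the flat result of the one measured step, compound 3 is expected to show a step of about a number 2.8 percentage points higher from compound 2 to compound 3 (within the scatter), that is, no change beyond the scatter, with the estimate for compound 3 in this assay at 35% within a range of 18% to 52%.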

Compound 3, a percentage reported as activity, at one dose (the size of the read-out at that dose, not a potency): 30.1%
Compound 3: middle estimate off by 4.9 percentage points, on the high side; the measured number falls inside the stated range.
By their numbers in this assay, from the lowest: compounds 3, 2 and 1 (each within the scatter of the next).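

In this assay, isopropyl, with 0 hydrogen-bond donors and 0 hydrogen-bond acceptors, on the saturated chain carbon bound to an amide-type nitrogen and a carbonyl carbon gives a number 2.1 percentage points lower from compound 2 to compound 3 (within the scatter), and set against 2-carbamoylethyl it gives a number 7.7 percentage points lower from compound 1 to compound 3 (within the scatter). The hydrogen-bond donor and acceptor of hydroxymethyl are therefore not required at this place to keep the number within the scatter, and the three groups shown cannot be ranked on this read-out. No measurement offered here bears on the reason for this flat result.

On these data alone, whether a carboxylic acid, an amine or a longer chain on this carbon would give a step beyond the scatter remains open. With a single dose throughout, the numbers also leave potency at this place open.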